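The compounds below may be only part of what the source reports. "The series", "measured", "known", "first", "only" and "open" are said of these compounds alone.

Measured compounds in a functional assay on MGC-803 cells (Homo sapiens) for cytotoxicity, read by MTT assay, with a stated time of 72 h; a lower number here means a stronger inhibitor, a higher number a weaker inhibitor:
compound 1 `COc1cc2ncnc(NNC(=S)NC(=O)c3ccc(F)cc3)c2cc1OC`: 8300 nM
compound 2 `O=C(NC(=S)NNc1ncnc2ccccc12)c1cccc(Cl)c1`: 4540 nM
compound 3 `COc1ccccc1C(=O)NC(=S)NNc1ncnc2ccccc12`: 14300 nM

Compound 1 stands second highest of the three numbers; its gaps to compound 3 and to compound 2 both lie within the scatter, so no order among the three is claimed. Compound 4 `COc1cc2ncnc(NNC(=S)NC(=O)c3ccc(C)cc3)c2cc1OC` differs from compound 1 by methyl in place of fluoro on an aromatic carbon. Among the measured compounds shown here, the only measured step, a 3.1-fold higher number from compound 2 to compound 3 (0.50 log units; beyond the scatter), exchanges the whole aryl group on the carbonyl and is modest; no measured step varies a single substituent on that ring while keeping the rest, so it bears on the present change only loosely. The expectation is therefore a step no larger than the scatter, in either direction, a 1.0-fold lower number from compound 1 to compound 4 (0.02 log units; within the scatter). Compound 4 is expected to give 8000 nM, within the range 4000 nM to 16000 nM.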

Compound 4, half-maximal inhibitory concentration: 19700 nM
Compound 4: the middle estimate sits 2.5-fold (0.39 log units) below what was measured; measured number above the stated range.
By their numbers in this assay, from the lowest: compounds 2, 1, 3 and 4 (each within the scatter of the next, the first and the last beyond it).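

In this assay, among the compounds shown here, the exchange of 4-fluorophenyl for 4-methylphenyl gives the first step in which a single substituent on this ring changes while the rest stays fixed (a 2.4-fold higher number from compound 1 to compound 4 (0.38 log units; beyond the scatter)). The position para to a large group therefore responds to replacing one heavy atom with another, which the whole-aryl exchange between compound 2 and compound 3 could not show. No available evidence accounts for this step.

As far as these compounds go, whether an amine or a carboxylic acid at this place would raise or lower the number remains open. So does whether the same exchange gives a similar step on the core of compound 2.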